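A few compounds are considered here, and "the series" means these few. Any claim that something is new, unique, unknown or untested is made for them only; others in the source may bear on it.

Compound 1 `O=C(c1cc(Cc2n[nH]c(=O)c3ccccc23)ccc1F)N1CCc2nc(N3CCCC3)ncc2C1` and compound 2 `O=C(c1cc(Cc2n[nH]c(=O)c3ccccc23)ccc1F)N1CCc2nc(N3CCCCC3)ncc2C1` share a core and both rest at a limit in a functional assay on MDA-MB-231 cells (Homo sapiens) for inhibition, read by MTT assay, with a stated time of 48 h; a higher number here means a weaker inhibitor, a lower number a stronger inhibitor. Compound 1 gives only the limit > 200000 nM. Compound 2 likewise gives only the limit > 200000 nM. The step that the two limits leave unreadable from compound 1 to compound 2 is thus not readable, both values sitting at the limit of > 200000 nM in this assay, at which 2 of the 2 values shown sit. Compound 3 `CN(C)CCN(C)c1ncc2c(n1)CCN(C(=O)c1cc(Cc3n[nH]c(=O)c4ccccc34)ccc1F)C2` carries (2-(dimethylamino)ethyl)(methyl)amino in place of piperidin-1-yl on an aromatic carbon. Among the compounds with values here, only that unreadable step bears on this change, so no step beyond the scatter is expected for a step that the limit leaves unreadable from compound 2 to compound 3. Compound 3 is estimated at 250000 nM, range 50000 nM to 1000000 nM, most probably reported again only as a limit.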

Compound 3, half-maximal inhibitory concentration: > 200000 nM
Compound 3 ended at the assay's limit (the forecaster's own chance of this, stated with the estimate: 85%); the middle value is on the limit's open side.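

No step can be read among compound 1, compound 2 and compound 3 in this assay, as each gives only a limit: the limit of > 200000 nM in this assay, at which 3 of the 3 values shown sit. Going by these compounds, whether these three compounds differ at all in this assay stays open.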